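The compounds below may be only part of what the source reports. "The series", "measured", "known", "first", "only" and "open" are said of these compounds alone.

Measured in a functional assay on MDA-MB-436 cells (Homo sapiens) for antiproliferative activity, read by MTT assay, with a stated time of 24 h; a lower number here means a stronger inhibitor, a higher number a weaker inhibitor:
- Compound 1 `COc1ccccc1C(=O)NC(CC(=O)O)c1ccccc1`: > 100000 nM
- Compound 2 `CC(C)(C)c1ccc(S(=O)(=O)NC(CC(=O)O)c2ccccc2)cc1`: > 100000 nM
- Compound 3 `O=C(O)CC(NS(=O)(=O)c1cc(F)cc(F)c1)c1ccccc1`: 69400 nM

Compound 2 stands at the limit of > 100000 nM in this assay, at which 2 of the 3 values shown sit. That value is a limit, not a number, and compound 1 also gives only a limit.

Compound 4 `O=C(O)CC(NS(=O)(=O)c1ccc(C(F)(F)F)cc1)c1ccccc1` is compound 2 with one change: trifluoromethyl in place of tert-butyl on an aromatic carbon. Among the compounds with values here, no measured pair shows the effect of such a change. Compound 3, at 69400 nM, shows that a number within reach of this assay is possible in this small set, so only a small strengthening is expected. The expected step is an at least 1.3-fold lower number from compound 2 to compound 4 (0.12 log units; that floor lies within the scatter), and the result may again be only a limit. For compound 4 the estimate is 75000 nM, with an expected range of 30000 nM to 100000 nM.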

Compound 4, half-maximal inhibitory concentration: 54700 nM
Compound 4: middle estimate off by 1.4-fold (0.14 log units), on the high side, and the stated range covers the measured number.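

In this assay, trifluoromethyl in place of tert-butyl on the aromatic carbon gives an at least 1.8-fold lower number from compound 2 to compound 4 (0.26 log units; that floor lies within the scatter). Compound 4 gives a number at this position where compound 2 gives only a limit. Going by these compounds, the true size of the step stays unknown, and the step is only a floor, because the starting point is a limit: the limit of > 100000 nM in this assay, at which 2 of the 4 values shown sit.

On these data alone, whether an amine or a nitrile at this same position would give a lower number remains open. So does how far the real value of compound 2 lies from that limit.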